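The source may hold more compounds than are shown below. What is called first, only, known or untested is meant among the compounds shown, and "the series" means these compounds.

Measured compounds:
compound 1 `O=C(Nc1ccc(-c2cscn2)cc1)C1CCCN(Cc2ccc(F)c(F)c2)C1`: 880 nM
compound 2 `O=C(Nc1ccc(-c2cscn2)cc1)C1CCCN(Cc2cccc(F)c2)C1`: 2450 nM
compound 3 `O=C(Nc1ccc(-c2cscn2)cc1)C1CCCN(Cc2cccc(F)c2F)C1`: 1480 nM

In a functional assay on A-375 cells (Homo sapiens) for antiproliferative activity (on this read-out higher numbers stand for weaker inhibition and lower numbers for stronger inhibition), compound 1 stands at the lowest of the three numbers; its nearest neighbour is compound 3 (a 1.7-fold higher number from compound 1 to compound 3 (0.23 log units; within the scatter), within the scatter), its furthest compound 2 (a 2.8-fold higher number from compound 1 to compound 2 (0.44 log units; beyond the scatter), beyond the scatter). Compound 4 `O=C(Nc1ccc(-c2ccc[nH]2)cc1)C1CCCN(Cc2ccc(F)c(F)c2)C1` differs from compound 1 by 1H-pyrrol-2-yl in place of 1,3-thiazol-4-yl on an aromatic carbon. For the measured compounds named here, none of the measured steps bears on this position: the steps of a 2.8-fold higher number from compound 1 to compound 2 (0.44 log units; beyond the scatter) and a 1.7-fold lower number from compound 2 to compound 3 (0.22 log units; within the scatter) both concern only the fluoro pattern of the benzyl group, and the shared core carrying the aryl ring is unchanged across compounds 1 to 3. Going by the values given here, with no comparable step in hand, no direction beyond the scatter is expected in this assay, and the estimate for compound 4 is set near compound 1 with a wide range. Compound 4 is therefore expected to give about 1200 nM, between 300 nM and 5000 nM, that is an expected step of a 1.4-fold higher number from compound 1 to compound 4 (0.13 log units; within the scatter).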

Compound 4, half-maximal inhibitory concentration: 360 nM
Estimate against measurement, compound 4: 3.3-fold (0.52 log units) above; the measured number falls inside the stated range.
By their numbers in this assay, from the lowest: compound 4; then compounds 1, 3 and 2 (each within the scatter of the next, the first and the last beyond it).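

In this assay, the aryl ring para to a large group proves to be a position that responds: a 2.4-fold lower number from compound 1 to compound 4 (0.39 log units; beyond the scatter) with 1H-pyrrol-2-yl in place of 1,3-thiazol-4-yl. Compounds 1 to 3 differed only in the fluoro pattern of the benzyl group, so this is the first change shown outside it. The change also exchanges 2 hydrogen-bond acceptors for 1 hydrogen-bond donor, but no available data explain the step.

On these data alone, whether the pyrrole hydrogen on nitrogen matters remains open, and a 1-methylpyrrol-2-yl or furan-2-yl group would test this. Also open, as far as these compounds go, is whether the fluoro pattern steps carry over to the 1H-pyrrol-2-yl series.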